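This account rests on a few compounds, and the source may have more. Where it says the series, first, only, none or still open, it means among the compounds named here.

Compounds measured so far: compound 1 `O=C(c1ccc(OCCCN2CC[C@H](NS(=O)(=O)c3ccc(F)cc3)C2)cc1)C1CC1` with 500 nM in an assay on isolated protein for binding affinity to histamine H2 receptor (Homo sapiens); a lower number here means a stronger inhibitor, a higher number a weaker inhibitor; compound 2 `O=C(N[C@H]1CCN(CCCOc2ccc(C(=O)C3CC3)cc2)C1)c1csc(-c2cccnc2)n1` with 4000 nM; compound 3 `O=C(c1ccc(OCCCN2CC[C@H](NS(=O)(=O)c3ccccc3F)C2)cc1)C1CC1` with 1550 nM.

Compound 2 gives the highest number of the three, lying beyond the scatter from compound 3 and further still from compound 1. Within the data shown here, the only measured step, a 3.1-fold higher number from compound 1 to compound 3 (0.49 log units; beyond the scatter), concerns the aryl group on the sulfonyl sulfur and so does not touch the part that changes here. Among the measured compounds shown here, compound 4 `CC(=O)c1ccc(OCCCN2CC[C@H](NC(=O)c3csc(-c4cccnc4)n3)C2)cc1` differs from compound 2 by methyl in place of cyclopropyl on a carbonyl carbon, a change for which no measured pair gives guidance. In its absence, the expected step of no change at the digits printed from compound 2 to compound 4 (within the scatter) is none beyond the scatter. Compound 4 is therefore estimated at 4000 nM, within a range of 1500 nM to 10000 nM.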

Compound 4, inhibition constant: 6200 nM
Compound 4: middle estimate off by 1.6-fold (0.19 log units), on the low side; the range from low to high includes it.
By their numbers in this assay, from the lowest: compound 1; then compound 3; then compounds 2 and 4 (each within the scatter of the next).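

Among these compounds, this is the first reading at the carbonyl carbon: methyl in place of cyclopropyl gives a 1.6-fold higher number from compound 2 to compound 4 (0.19 log units; within the scatter) in this assay and so leaves the two compounds indistinguishable. On this core, then, the three-membered ring can give way to a single carbon with no step beyond the scatter. Nothing shown here bears on why this is so. Going by these compounds, whether a phenyl or an amine on that carbonyl carbon would shift the number remains open. So does whether the same swap would read alike on the core of compound 1.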